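The source may report more compounds than this note shows. Statements on the series, on what has been measured and on what is new or still open speak of the compounds shown alone.

Measured in an assay on HEK293 cells for displacement of a labelled ligand from melanin-concentrating hormone receptor 1 (Homo sapiens); on this read-out higher numbers stand for weaker inhibition and lower numbers for stronger inhibition:
Compound 1 `O=C(NC1CCN(Cc2ccn(-c3ccc(C(F)(F)F)cc3)c2)CC1)NS(=O)(=O)c1ccc(F)cc1` gives 617 nM.
Compound 2 `O=C(NC1CCN(Cc2ccn(-c3ccc(C(F)(F)F)cc3)c2)CC1)N1CCn2cccc2C1c1ccccc1` gives 10 nM.
Compound 3 `O=C(NC1CCN(Cc2ccn(-c3ccc(C(F)(F)F)cc3)c2)CC1)N1CC[C@H](O)C1` gives 125 nM.

Compound 3 sits in the middle of these three numbers: the step of a 4.9-fold lower number from compound 1 to compound 3 (0.69 log units; beyond the scatter) separates it from compound 1, while compound 2 shows a clearly lower number still. Compound 4 `O=C(NC1CCN(Cc2ccn(-c3ccc(C(F)(F)F)cc3)c2)CC1)N1CC[C@@H](O)C1` differs from compound 3 in a single respect: the two compounds have the same atoms and bonds and differ only in configuration as drawn: 1 of 1 stereo elements differ; a stereocentre at a saturated ring carbon is drawn S in compound 3 and R in compound 4. None of the measured steps involves a change of configuration; the only measured step, a 4.9-fold lower number from compound 1 to compound 3 (0.69 log units; beyond the scatter), exchanged a whole group for another, so nothing shown here bears directly on this move. The expectation is therefore a step of a 1.1-fold higher number from compound 3 to compound 4 (0.05 log units; within the scatter) in this assay, with no direction favoured and wide uncertainty. Compound 4 is estimated at 140 nM, within a range from 50 nM to 450 nM.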

Compound 4, half-maximal inhibitory concentration: 138 nM
The estimate for compound 4 lay 1.0-fold (0.01 log units) above the measured number; measured number inside the range.
By their numbers in this assay, from the lowest: compound 2; then compounds 3 and 4 (each within the scatter of the next); then compound 1.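

In this assay, among the compounds shown here, the step of a 1.1-fold higher number from compound 3 to compound 4 (0.04 log units; within the scatter) shows that the drawn configuration of the 3-hydroxypyrrolidin-1-yl group makes no visible difference here, which no earlier pair could show. The gain from exchanging ((4-fluorophenyl)sulfonyl)amino for this group also holds for the other configuration, with a 4.5-fold lower number from compound 1 to compound 4 (0.65 log units; beyond the scatter). This reading of configuration rests on a matched pair: the fact that compounds 3 and 4 differ only in the configuration as drawn

Going by these compounds, it remains open whether an amine or a methoxy group in place of the hydroxyl would give a similar number. On these data alone, it also remains open whether the two configurations would then still match.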